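Swapping methoxy for fluoro on the sulfonyl aryl ring

The source may hold more compounds than are shown below. What is called first, only, known or untested is meant among the compounds shown, and "the series" means these compounds.

Of the compounds shown here, three sharing one core have been measured in an ADME assay on microsomes from liver (Homo sapiens) for metabolic stability, tested at 2.5 uM; a lower number here means slower removal, a higher number faster removal of the compound. Compound 1 `COc1ccc(-c2c(S(=O)(=O)c3ccc(F)c(F)c3)cnc3cc(F)ccc23)cc1` gives 1.1 mL/min, compound 2 `O=S(=O)(c1ccc(F)cc1)c1cnc2cc(F)ccc2c1-c1ccc(F)cc1` gives 1.34 mL/min, and compound 3 `COc1ccc(-c2c(S(=O)(=O)c3ccc(OC)cc3)cnc3cc(F)ccc23)cc1` gives 1.18 mL/min. Compound 3 stands second highest of the three; its nearest neighbour is compound 1 and its furthest is compound 2, and both of those gaps fall within the scatter, so no order among the three can be claimed. Among the measured compounds shown here, the one recorded step with a single change, a 1.1-fold higher number from compound 1 to compound 3 (0.03 log units; within the scatter), lies within the scatter as well.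

Compound 4 `COc1ccc(-c2c(S(=O)(=O)c3ccc(F)cc3)cnc3cc(F)ccc23)cc1` differs from compound 3 as follows: fluoro in place of methoxy on an aromatic carbon. The step from compound 1 to compound 3 concerns the same sulfonyl aryl ring and moved the number hardly at all, and compound 2, which also carries a 4-fluorophenyl on the sulfonyl sulfur, gives a number close to that of compound 3. The expectation for compound 4 in this assay is therefore a step of a 1.0-fold higher number from compound 3 to compound 4 (0.01 log units; within the scatter), not beyond the scatter. Compound 4 is estimated at 1.2 mL/min, with a range from 0.7 mL/min to 2.2 mL/min.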

Compound 4, intrinsic clearance in a liver preparation (reported as CLH), per the amount of preparation that the assay uses: 1.77 mL/min
Compound 4: the middle estimate sits 1.5-fold (0.17 log units) below what was measured; the measured number falls inside the stated range.
By their numbers in this assay, from the lowest: compounds 1, 3, 2 and 4 (each within the scatter of the next).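

In this assay, 4-fluorophenyl in place of 4-methoxyphenyl on the sulfonyl sulfur gives a 1.5-fold higher number from compound 3 to compound 4 (0.18 log units; within the scatter) and so stays inside the usual variation at this position. The two other single changes that lead to compound 4 also stay inside it: methoxy in place of fluoro on an aromatic carbon gives a 1.3-fold higher number from compound 2 to compound 4 (0.12 log units; within the scatter) and hydrogen in place of fluoro on an aromatic carbon gives a 1.6-fold higher number from compound 1 to compound 4 (0.21 log units; within the scatter) without any clear order among the compounds. No supporting evidence bears on these results, so the numbers alone offer no explanation.

The compounds shown carry only fluoro, methoxy or hydrogen at the positions that vary. Going by these compounds, whether an amine or a carboxylic acid on the sulfonyl aryl ring would produce a step beyond the usual variation remains open.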